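The compounds below may be only part of what the source reports. "The series", "measured", "known", "first", "only" and "open" are said of these compounds alone.

Measured so far:
compound 1 `COC(=O)c1c(F)cccc1OC(=O)COc1cc(O)c2c(=O)cc(-c3ccccc3)oc2c1` — 319000 nM
compound 2 `COC(=O)c1c(C)cccc1OC(=O)COc1cc(O)c2c(=O)cc(-c3ccccc3)oc2c1` — 298000 nM

Both numbers come from an ADME assay on cells (T-cell, Mus musculus, strain BALB/c) for cytotoxicity, read by MTT assay, with a stated time of 48 h; on this read-out lower numbers stand for higher toxicity in this test and higher numbers for lower toxicity in this test. Of the two, compound 1 holds the larger number, but only by a 1.1-fold lower number from compound 1 to compound 2 (0.03 log units; within the scatter), so the pair is indistinguishable. Compound 3 `COC(=O)c1cc(Br)ccc1OC(=O)COc1cc(O)c2c(=O)cc(-c3ccccc3)oc2c1` is not yet measured; it differs from compound 1 by 4-bromo-2-(methoxycarbonyl)phenyl in place of 3-fluoro-2-(methoxycarbonyl)phenyl on an oxygen next to a carbonyl group. Within the data shown here, the single measured step, methyl in place of fluoro on an aromatic carbon, is a different change and stayed within the scatter, so no step beyond the scatter is expected here. Compound 3 is therefore expected to give 300000 nM, in the range 150000 nM to 600000 nM. The expected step is a 1.1-fold lower number from compound 1 to compound 3 (0.03 log units; within the scatter).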

Compound 3, half-maximal cytotoxic concentration: > 450000 nM
Compound 3 gave a limit, no number (the forecaster's own chance of this, stated with the estimate: 15%); middle value at least 1.5-fold (0.17 log units) from the limit.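

In this assay, compound 3 is recorded only as a limit, not as a number: the limit of > 450000 nM in this assay, at which 1 of the 3 values shown sits.

Placing 4-bromo-2-(methoxycarbonyl)phenyl in place of 3-fluoro-2-(methoxycarbonyl)phenyl on this oxygen gives an at least 1.4-fold higher number from compound 1 to compound 3 (0.14 log units; that floor lies within the scatter), and the second comparison gives an at least 1.5-fold higher number from compound 2 to compound 3 (0.17 log units; that floor lies within the scatter). From the compounds shown here alone, the bromo group therefore brings no lower number at this position, while the true size of both steps stays unknown.

Still open, going by these compounds, is whether a carboxylic acid in place of the methoxycarbonyl, or an amine on the phenyl ring, would bring the number down.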